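A few compounds are considered here, and "the series" means these few. Any claim that something is new, unique, unknown or untested is made for them only; others in the source may bear on it.

Series notes. Compound 1 `O=C(Nc1cccc(-n2cc(-c3ccncc3)c(-c3cc(O)cc(Cl)c3)n2)c1)Nc1ccc(Cl)c(C(F)(F)F)c1` gives -52% in a functional assay on OVCAR-8 cells (Homo sapiens) for inhibition, read by sulforhodamine B assay, with a stated time of 48 h, tested at 100 uM; on this read-out lower numbers stand for a stronger effect and higher numbers for a weaker effect at the one concentration tested. Compound 2 `O=C(Nc1cccc(-n2cc(-c3ccncc3)c(-c3cc(O)cc(Cl)c3)n2)c1)Nc1ccc(Cl)c(Cl)c1` gives -38% in this assay, and compound 3 `COc1cc(Cl)cc(-c2nn(-c3cccc(NC(=O)Nc4ccc(Cl)c(C(F)(F)F)c4)c3)cc2-c2ccncc2)c1` gives -33% in this assay. Among the three measured numbers compound 3 stands highest; its gap to compound 2 lies within the scatter, whereas a number 19 percentage points higher from compound 1 to compound 3 (beyond the scatter) lies beyond it. The step under consideration leads to compound 4 `COc1cc(Cl)cc(-c2nn(-c3cccc(NC(=O)Nc4ccc(Cl)c(Cl)c4)c3)cc2-c2ccncc2)c1`, which differs from compound 3 by chloro in place of trifluoromethyl on an aromatic carbon. Exactly one measured step is of the same kind: a number 14 percentage points higher from compound 1 to compound 2 (beyond the scatter), a modest move beyond the scatter. For the measured compounds named here, no other measured step bears on this change, so the precedent is a single pair. Given a number 14 percentage points higher from compound 1 to compound 2 (beyond the scatter), a step of similar size and in the same direction is expected here: a number 14 percentage points higher from compound 3 to compound 4 (beyond the scatter). In this assay compound 4 is accordingly estimated at -19%, with the number expected to fall between -36% and -2%.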

Compound 4, a percentage reported as activity, at one concentration (the size of the read-out at that concentration, not a potency): -9%
Compound 4: the middle estimate sits 10 percentage points below what was measured, and the stated range covers the measured number.
By their numbers in this assay, from the lowest: compound 1; then compounds 2 and 3 (each within the scatter of the next); then compound 4.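

Chloro in place of trifluoromethyl now gives a number 24 percentage points higher from compound 3 to compound 4 (beyond the scatter), so in this assay this change weakens the effect with methyl on the oxygen as well as with hydrogen there: the same change on two cores in this assay, a number 14 percentage points higher (beyond the scatter) from compound 1 to compound 2 and a number 24 percentage points higher (beyond the scatter) from compound 3 to compound 4, 10 percentage points apart, within the scatter of two such steps. Methyl in place of hydrogen on the oxygen also repeats its direction with the 3,4-dichlorophenyl group, as a number 29 percentage points higher from compound 2 to compound 4 (beyond the scatter): the same change on two cores in this assay, a number 19 percentage points higher (beyond the scatter) from compound 1 to compound 3 and a number 29 percentage points higher (beyond the scatter) from compound 2 to compound 4, 10 percentage points apart, within the scatter of two such steps. Across these four compounds, neither change shows a step that differs beyond the scatter when the other change is present, and no compound goes against this.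

On these data alone, whether the same direction holds for other groups on that aromatic carbon, such as bromo, methyl or nitrile, remains open, as does the effect of a longer chain in place of methyl on the oxygen. With one concentration and one cell line, the compounds leave the effect at other concentrations and any wider cellular pattern unresolved.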